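Working notes: from compound 3 to compound 4

A few compounds are considered here, and "the series" means these few. Any claim that something is new, unique, unknown or untested is made for them only; others in the source may bear on it.

Of the compounds shown here, three on one shared core have been measured in a functional assay on HT-29 cells (Homo sapiens) for cytotoxicity, read by MTT assay, with a stated time of 24 h, tested at 32 ug/mL; a lower number here means a weaker effect, a higher number a stronger effect of the compound at the concentration tested. In this assay compound 1 `CCN1CCN(CC(=O)Nc2ccc(-c3nc(-c4ccccc4)c(-c4ccccc4)n3C)cc2)CC1` gives 38.8%, compound 2 `Cn1c(-c2ccc(NC(=O)CN3CCN(Cc4ccccc4)CC3)cc2)nc(-c2ccccc2)c1-c1ccccc1` gives 40%, and compound 3 `COc1ccc(CN2CCN(CC(=O)Nc3ccc(-c4nc(-c5ccccc5)c(-c5ccccc5)n4C)cc3)CC2)cc1` gives 29.9%. Compound 3 holds the lowest of the three numbers. The step of a number 8.9 percentage points lower from compound 1 to compound 3 (within the scatter) is within the scatter, as is a number 1.2 percentage points higher from compound 1 to compound 2 (within the scatter); only a number 10.1 percentage points lower from compound 2 to compound 3 (beyond the scatter) reaches beyond it, and only modestly.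

The unmeasured compound 4 `Cn1c(-c2ccc(NC(=O)CN3CCN(Cc4ccc(Cl)cc4)CC3)cc2)nc(-c2ccccc2)c1-c1ccccc1` differs from compound 3 in one place: chloro in place of methoxy on an aromatic carbon. Going by the values given here, the one measured step that touches this position is the modest drop a number 10.1 percentage points lower from compound 2 to compound 3 (beyond the scatter), where methoxy replaced hydrogen on an aromatic carbon. Among the compounds with values here, no measured step introduces chloro anywhere, so the effect of that group in this assay is unknown. Taking away the methoxy alone would, on the evidence of compound 2, be expected to recover the modest loss; what the entering chloro adds or removes cannot be read from the three compounds. The step of a number 7.1 percentage points higher from compound 3 to compound 4 (within the scatter) is therefore expected to be small, most likely upward and close to the scatter. Compound 4 is estimated at 37%, with a range from 26% to 48%.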

Compound 4, a percentage reported as activity, at one concentration (the size of the read-out at that concentration, not a potency): 55.6%
Estimate against measurement, compound 4: 18.6 percentage points below; the whole stated range lies below it.
By their numbers in this assay, from the lowest: compounds 3, 1 and 2 (each within the scatter of the next, the first and the last beyond it); then compound 4.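

In this assay, going by these compounds alone, the aromatic carbon para to a large group can carry the number upward, which the earlier compounds did not show: methoxy in place of hydrogen there gave a number 10.1 percentage points lower from compound 2 to compound 3 (beyond the scatter), whereas chloro in place of hydrogen gives a number 15.6 percentage points higher from compound 2 to compound 4 (beyond the scatter). The two groups therefore move the number in opposite directions from the same carbon, and exchanging one for the other gives a number 25.7 percentage points higher from compound 3 to compound 4 (beyond the scatter). On the saturated chain carbon bound to the ring amine nitrogen, 4-chlorophenyl in place of methyl gives a number 16.8 percentage points higher from compound 1 to compound 4 (beyond the scatter), while phenyl gives a number 1.2 percentage points higher from compound 1 to compound 2 (within the scatter) and 4-methoxyphenyl gives a number 8.9 percentage points lower from compound 1 to compound 3 (within the scatter), so among these three groups only the chlorinated one clears the scatter.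

No supporting measurement is available to explain why chloro and methoxy differ at this carbon. From the compounds shown here alone, it remains open whether fluoro, bromo or trifluoromethyl at the same carbon would follow chloro, and whether chloro on another carbon of that aromatic ring would keep the gain.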